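A few compounds are considered here, and "the series" means these few. Any claim that something is new, unique, unknown or untested is made for them only; others in the source may bear on it.

Measured compounds in a functional assay on A549 cells (Homo sapiens) for antiproliferative activity, read by MTT assay, with a stated time of 24 h; on this read-out lower numbers stand for stronger inhibition and higher numbers for weaker inhibition:

Compound 1 `O=C(NNC(=O)c1ccccc1Cl)c1ccc(NS(=O)(=O)c2cnc(O)nc2O)cc1` — 1900 nM
Compound 2 `O=C(NNC(=O)c1cccc(Cl)c1)c1ccc(NS(=O)(=O)c2cnc(O)nc2O)cc1` — 2290 nM
Compound 3 `O=C(NNC(=O)c1ccccc1NS(=O)(=O)c1cnc(O)nc1O)c1ccccc1Cl` — 5290 nM

Compounds 1 and 2 share one core; compound 3 carries another, and the difference between the two cores is not broken down here. Within the first pair the single change is 3-chlorophenyl in place of 2-chlorophenyl on a carbonyl carbon. It gives a 1.2-fold higher number from compound 1 to compound 2 (0.08 log units; within the scatter), so compounds 1 and 2 cannot be told apart on this read-out. Compound 3 stands apart: its number is higher than that of compound 2 and that of compound 1, and both gaps lie beyond the scatter.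

Compound 4 `O=C(NNC(=O)c1ccccc1NS(=O)(=O)c1cnc(O)nc1O)c1cccc(Cl)c1` is not yet measured. It differs from compound 3 by 3-chlorophenyl in place of 2-chlorophenyl on a carbonyl carbon, the same change, at the same place, that separates compound 2 from compound 1. Among the compounds with values here, the only precedent for this change is the step from compound 1 to compound 2, which stayed within the scatter; the step from compound 3 to compound 4 is therefore expected to be of similar size, a 1.1-fold higher number from compound 3 to compound 4 (0.05 log units; within the scatter), because the value of compound 3 5290 nM is taken as the starting point and no effect beyond scatter was seen before. The expected value for compound 4 in this assay is 6000 nM, with a range of 3000 nM to 12000 nM; the width of that range reflects that the change has been observed only once and on a different core.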

Compound 4, half-maximal inhibitory concentration: 1260 nM
Estimate against measurement, compound 4: 4.8-fold (0.68 log units) above, outside the stated range (below it).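

In this assay, 3-chlorophenyl in place of 2-chlorophenyl on a carbonyl carbon gives a 4.2-fold lower number from compound 3 to compound 4 (0.62 log units; beyond the scatter), so on the core of compound 3 this change has a measurable effect. The change therefore does not carry over from one core to the other at the same size, and the step seen on the core of compound 1 is a poor guide to the step on the core of compound 3: the same change on two cores in this assay, a 1.2-fold higher number (0.08 log units; within the scatter) from compound 1 to compound 2 and a 4.2-fold lower number (0.62 log units; beyond the scatter) from compound 3 to compound 4, 5.1-fold (0.70 log units) apart, beyond the scatter of two such steps This rests on a single pair of compounds per core, so it shows that the outcome of the change depends on the core in these four compounds, but it does not show which structural difference between the two cores is responsible, nor does it give a rule for any further core.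

Going by these compounds, it remains open whether the dependence on the core is specific to chlorine or also holds for an unsubstituted phenyl ring or for a phenyl ring carrying a methoxy group or a carboxylic acid on the same carbonyl carbon. Also open, on these data alone, is whether the step from compound 3 to compound 4 would be repeated with either of these groups on the core of compound 3.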